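Acetyl in place of nitro on the shared core

The source may hold more compounds than are shown below. What is called first, only, known or untested is meant among the compounds shown, and "the series" means these compounds.

Three compounds share one core and differ only in the group on an aromatic carbon. Compound 1 `CCc1ccc(/C=C/[C@@H]2CCCCN2)cc1` gives 5.94 ug/mL in a functional assay on A549 cells (Homo sapiens) for inhibition, read by MTT assay, with a stated time of 24 h; on this read-out lower numbers stand for stronger inhibition and higher numbers for weaker inhibition. Compound 2 `FC(F)(F)c1ccc(/C=C/[C@@H]2CCCCN2)cc1` gives 2.82 ug/mL in this assay, and compound 3 `O=[N+]([O-])c1ccc(/C=C/[C@@H]2CCCCN2)cc1` gives 3.27 ug/mL. Compound 3 stands second highest of the three numbers: the step of a 1.2-fold higher number from compound 2 to compound 3 (0.06 log units; within the scatter) lies within the scatter, as does the step of a 1.8-fold lower number from compound 1 to compound 3 (0.26 log units; within the scatter). Compound 4 `CC(=O)c1ccc(/C=C/[C@@H]2CCCCN2)cc1` differs from compound 3 in one place: acetyl in place of nitro on an aromatic carbon. Going by the values given here, the steps that bear on this change are all exchanges at the same aromatic carbon. The step of a 2.1-fold lower number from compound 1 to compound 2 (0.32 log units; beyond the scatter) is modest, while a 1.8-fold lower number from compound 1 to compound 3 (0.26 log units; within the scatter) and a 1.2-fold higher number from compound 2 to compound 3 (0.06 log units; within the scatter) stay within the scatter. Every exchange of this group so far has moved the number little, so compound 4 is expected to show no step beyond the scatter in this assay. Compound 4 is therefore estimated at 4 ug/mL, with a range from 2 ug/mL to 8 ug/mL. The expected step is a 1.2-fold higher number from compound 3 to compound 4 (0.09 log units; within the scatter).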

Compound 4, half-maximal inhibitory concentration: 3.69 ug/mL
Compound 4: middle estimate off by 1.1-fold (0.04 log units), on the high side; low and high end bracket the measured number.
By their numbers in this assay, from the lowest: compounds 2, 3, 4 and 1 (each within the scatter of the next, the first and the last beyond it).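

Acetyl in place of nitro adds a fourth group at this aromatic carbon, and in this assay the new compound stays within the scatter of all three others, as the steps show (a 1.1-fold higher number from compound 3 to compound 4 (0.05 log units; within the scatter)) (a 1.3-fold higher number from compound 2 to compound 4 (0.12 log units; within the scatter)) (a 1.6-fold lower number from compound 1 to compound 4 (0.21 log units; within the scatter)). The exchange swaps nitrogen for carbon in a group of the same heavy-atom count and drops the hydrogen-bond acceptors from two to one, and this assay does not separate the two compounds. Going by these compounds alone, the only step beyond the scatter among the four compounds remains the modest one between ethyl and trifluoromethyl (a 2.1-fold lower number from compound 1 to compound 2 (0.32 log units; beyond the scatter)), and no measurement at hand accounts for the small size of these steps.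

On these data alone, it remains open whether an amine, a carboxylic acid or a longer chain at this aromatic carbon would produce a larger step. The compounds also leave open whether these small differences would hold on cells other than those used here.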